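The compounds below may be only part of what the source reports. "The series", "measured", "known", "first", "only" and "open" are said of these compounds alone.

Compound 1 `CC(C)c1c(C(=O)N2CCC[C@H](c3ccccc3)C2)nn(-c2ccc(F)cc2)c1OC[C@@H](O)C[C@@H](O)CC(=O)O` gives 4.8 nM in an assay on microsomes from liver for inhibition of 3-hydroxy-3-methylglutaryl-coenzyme A reductase (Rattus norvegicus); a higher number here means a weaker inhibitor, a lower number a stronger inhibitor. Compound 2 `COCc1cccc(CNC(=O)c2nn(-c3ccc(F)cc3)c(OC[C@@H](O)C[C@@H](O)CC(=O)O)c2C(C)C)c1` gives 31 nM, and compound 3 `COc1cccc(CN(C)C(=O)c2nn(-c3ccc(F)cc3)c(OC[C@@H](O)C[C@@H](O)CC(=O)O)c2C(C)C)c1` gives 21 nM. Compound 3 thus stands second highest of the three numbers, nearest to compound 2 and furthest from compound 1, as a 4.4-fold higher number from compound 1 to compound 3 (0.64 log units; beyond the scatter) shows. Compound 4 `CC(C)c1c(C(=O)N(C)Cc2ccc(F)c(F)c2)nn(-c2ccc(F)cc2)c1OC[C@@H](O)C[C@@H](O)CC(=O)O` differs from compound 3 by 3,4-difluorophenyl in place of 3-methoxyphenyl on a saturated chain carbon bound to an amide-type nitrogen. Among the compounds with values here, no measured step touches exactly this change. The nearest, a 1.5-fold lower number from compound 2 to compound 3 (0.17 log units; within the scatter), also alters the benzyl amide and stays within the scatter, while a 6.5-fold higher number from compound 1 to compound 2 (0.81 log units; beyond the scatter) and a 4.4-fold higher number from compound 1 to compound 3 (0.64 log units; beyond the scatter) show that even larger changes on the carbonyl carbon moved the number only modestly. A step within the scatter is therefore expected, a 1.1-fold lower number from compound 3 to compound 4 (0.02 log units; within the scatter). Compound 4 is estimated at 20 nM, between 8 nM and 50 nM.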

Compound 4, half-maximal inhibitory concentration: 5.7 nM
Estimate against measurement, compound 4: 3.5-fold (0.55 log units) above; the measured number lies below the stated range.
By their numbers in this assay, from the lowest: compounds 1 and 4 (each within the scatter of the next); then compounds 3 and 2 (each within the scatter of the next).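

In this assay the group on a saturated chain carbon bound to an amide-type nitrogen proves able to move the number, since 3,4-difluorophenyl in place of 3-methoxyphenyl gives a 3.7-fold lower number from compound 3 to compound 4 (0.57 log units; beyond the scatter) where the earlier change among benzyl amides stayed within the scatter. The same group gives a 5.4-fold lower number from compound 2 to compound 4 (0.74 log units; beyond the scatter) and a 1.2-fold higher number from compound 1 to compound 4 (0.07 log units; within the scatter), so an open-chain benzyl amide matches the 3-phenylpiperidin-1-yl amide. Nothing available explains this difference between the two aryl groups. As far as these compounds go, whether plain phenyl, 4-fluorophenyl or 3,4-dichlorophenyl would behave like 3,4-difluorophenyl remains open, as does the effect of this group on the amide without the methyl.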